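Removing One Chlorine from a Weak Growth Inhibitor

The compounds below may be only part of what the source reports. "The series", "measured", "known", "first", "only" and "open" are said of these compounds alone.

- Compound 1 `COc1cc(-n2cc(-c3ccc(Cl)cc3)[nH]c2=O)cc(OC)c1OC`: 25100 nM
- Compound 2 `COc1ccc(-n2cc(-c3ccc(OC)c(OC)c3)[nH]c2=S)cc1Cl`: > 100000 nM (a limit of the assay, not a number)

Going by the values given here, only two compounds have been tested so far in a functional assay on UACC-62 cells (Homo sapiens) for antiproliferative activity; on this read-out higher numbers stand for weaker inhibition of growth and lower numbers for stronger inhibition of growth. Among the compounds with values here, compound 1, at 25100 nM, holds the only true number, so it cannot yet be placed within a series. Compound 2 sits at > 100000 nM, which is a limit of the assay.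

The next compound is compound 3 `COc1cc(-n2cc(-c3ccccc3)[nH]c2=O)cc(OC)c1OC`. It keeps the core of compound 1 but has hydrogen in place of chloro on an aromatic carbon, para to a large group, turning 4-chlorophenyl into phenyl (hydrogen in place of chloro on an aromatic carbon).

Within the data shown here, no measured pair of compounds shows what this exchange does, so the expectation starts from compound 1 at 25100 nM. A small shift towards weaker inhibition of growth is expected, and it may stay within the usual scatter of repeat measurements. The expected change is a 1.4-fold higher number from compound 1 to compound 3 (0.14 log units; within the scatter). For compound 3 the estimated value is 35000 nM, with an expected range of 12000 nM to 100000 nM.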

Compound 3, concentration for 50% growth inhibition: 39800 nM
Compound 3: middle estimate off by 1.1-fold (0.06 log units), on the low side; the range from low to high includes it.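

In this assay, going by these compounds alone, the exchange of 4-chlorophenyl for phenyl gives the first step that can be read at this position: a 1.6-fold higher number from compound 1 to compound 3 (0.20 log units; within the scatter). This step lies within the usual scatter, so this read-out cannot tell compound 1 and compound 3 apart, and the chloro on this aromatic carbon, para to a large group, can go without a clear loss of growth inhibition. Compound 3 also gives a true number rather than a limit, so the core of compound 1 keeps a measurable, though weak, effect on growth with hydrogen at this place, and the number still has room to rise before it reaches the end of the assay's range: the limit of > 100000 nM in this assay, at which 1 of the 3 values shown sits.

As far as these compounds go, one exchange compares only chloro with hydrogen, so it remains open whether a larger or very different group on the same carbon, such as trifluoromethyl, an amine or a carboxylic acid, would move the number beyond the scatter in either direction. Within the data shown here, compound 2 differs from compound 1 and compound 3 in more than one place, so it gives no step that can be read for this position.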